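The source may hold more compounds than are shown below. What is called first, only, known or untested is meant among the compounds shown, and "the series" means these compounds.

Of the compounds shown here, two have been measured in a functional assay on CHO cells for antagonist activity at Orexin/Hypocretin receptor type 1 (Homo sapiens), read by FLIPR and calcium flux; a higher number here means a more potent compound, by a factor of ten per unit of this negative logarithm, a lower number a less potent compound. Compound 1, `Cc1nc(C(=O)N2CC3(CC3)C[C@H]2CNc2ncc(Cl)cn2)c(-c2ccccc2)s1`, gives 6.8 in this assay. Compound 2, `Cc1ccc(-n2nccn2)c(C(=O)N2CC3(CC3)C[C@H]2CNc2ccc(Cl)cn2)c1`, gives 8.1 in this assay, the higher of the two numbers; compound 1 is lower by a gap beyond the usual scatter. These two compounds differ in more than one part of their structures, so the difference between them cannot be traced to a single change.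

Compound 3, `Cc1ccc(-c2ncccn2)c(C(=O)N2CC3(CC3)C[C@H]2CNc2ccc(Cl)cn2)c1`, has not yet been measured. It differs from compound 2 in one place: pyrimidin-2-yl in place of 2H-1,2,3-triazol-2-yl on an aromatic carbon. The rest of the molecule, including the shared core and the group it carries on the other side, stays the same.

Among the compounds with values here, no measured pair shows what this particular exchange does in this assay, so the expectation rests on compound 2 alone. Compound 3 is expected to stay close to compound 2, with a step of a number 0.20 log units lower from compound 2 to compound 3 (within the scatter) that is not expected to go beyond the scatter in either direction. For compound 3 the estimate in this assay is 7.9, within a range from 7.3 to 8.5.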

Compound 3, negative logarithm of the antagonist equilibrium constant: 8.2
For compound 3 the middle estimate is 0.30 log units below the measured one; the range from low to high includes it.
By their numbers in this assay, from the lowest: compound 1; then compounds 2 and 3 (each within the scatter of the next).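

In this assay, the step for pyrimidin-2-yl in place of 2H-1,2,3-triazol-2-yl is a number 0.10 log units higher from compound 2 to compound 3 (within the scatter), so compound 2 and compound 3 cannot be told apart by this measurement. At this place, on an aromatic carbon ortho to a large group and para to a methyl group, a six-membered aromatic ring with 2 hetero atoms and a five-membered aromatic ring with 3 hetero atoms therefore read alike, which the earlier pair, differing in more than one part, could not show. No supporting measurement bears on why these two groups read alike.

The compounds shown leave open whether an aromatic ring is needed at this place at all, and how a simple amine, a methoxy group or a pyridin-2-yl ring would read there. They also leave open whether the same exchange would read alike on another framework, such as that of compound 1, which carries neither of these two groups.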